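Swapping the chain-end aryl group in compound 2

This account rests on a few compounds, and the source may have more. Where it says the series, first, only, none or still open, it means among the compounds named here.

Measured so far:
- compound 1 `Cc1c(F)cccc1CCCCOc1ccc(/C=C/c2cccc3c(CCCC(=O)O)c(C)n(CC(=O)O)c23)cc1`: 83%
- compound 2 `Cc1c(F)cccc1CCCCOc1ccc(/C=C/c2cccc3c(CCCC(=O)O)cn(CC(=O)O)c23)cc1`: 73%

Both compounds were tested in a functional assay on the whole organism for inhibition, with Cavia porcellus as the target, with stated times of 1 h and 10 min, at a dose of 0.3 mg/kg by the oral route; on this read-out lower numbers stand for a weaker effect and higher numbers for a stronger effect at the one dose given. Compound 2 gives 73%, the lower of the two numbers, while compound 1 gives 83%; the change a number 10 percentage points lower from compound 1 to compound 2 (within the scatter) sits within the scatter, so the two results cannot be told apart.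

Compound 3 `O=C(O)CCCc1cn(CC(=O)O)c2c(/C=C/c3ccc(OCCCCOc4ccccc4)cc3)cccc12` differs from compound 2 by phenoxy in place of 3-fluoro-2-methylphenyl on a saturated chain carbon, four bonds along the chain from an oxygen on an aromatic ring. Among the measured compounds shown here, the only measured step concerns hydrogen in place of methyl on the shared core, far from the chain end, so it says nothing about this change. For the measured compounds named here, with no bearing step, the expectation rests on compound 2 alone. The estimated step of a number 8 percentage points lower from compound 2 to compound 3 (within the scatter) is expected to be small, with a wide range in either direction. For compound 3 the expected value is 65%, between 40% and 85%.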

Compound 3, a percentage reported as inhibition, in the whole organism at one dose (the size of the read-out at that dose, not a potency): 37%
Beside the measured number, compound 3's estimate is 28 percentage points above it, outside the stated range (below it).
By their numbers in this assay, from the lowest: compound 3; then compounds 2 and 1 (each within the scatter of the next).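

At this position the chain end matters: in this assay, phenoxy in place of 3-fluoro-2-methylphenyl gives a number 36 percentage points lower from compound 2 to compound 3 (beyond the scatter), a step beyond the scatter, whereas the earlier change on the shared core stayed within it. The swap alters more than one feature at once, since the ring loses its fluorine and methyl while an oxygen and one hydrogen-bond acceptor enter at the chain carbon. Nothing measured here explains the size of this loss.

The compounds shown leave open whether the oxygen or the missing ring substituents account for the step. A 3-fluoro-2-methylphenoxy group, which keeps the substituted ring and adds the oxygen, and a plain phenyl group, which drops the substituents without adding oxygen, would each separate these two changes.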